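The source may report more compounds than this note shows. Statements on the series, on what has been measured and on what is new or still open speak of the compounds shown alone.

Measured compounds so far:

compound 1 `Cc1nc2nc(SCc3ccc(Cl)cc3)nn2c(N2CC[C@@H](C)[C@@H](N(C)c3ncnc4[nH]ccc34)C2)c1C` — > 100000 nM
compound 2 `Cc1cc(N2CC[C@@H](C)[C@@H](N(C)c3ncnc4[nH]ccc34)C2)n2nc(SCC3CCCCC3)nc2n1` — 11500 nM
compound 3 `CCCCCc1c(C)nc2nc(SCc3ccc(Cl)cc3)nn2c1N1CC[C@@H](C)[C@@H](N(C)c2ncnc3[nH]ccc23)C1` — > 100000 nM

Within the data shown here, in a functional assay on HGC-27 cells (Homo sapiens) for inhibition, read by MTT assay, with a stated time of 72 h (on this read-out lower numbers stand for stronger inhibition and higher numbers for weaker inhibition), compound 2 gives 11500 nM, the only number among the three values shown. The other two values are limits. For compound 1 the value > 100000 nM is a limit of this assay. For compound 3 the value > 100000 nM is likewise a limit of this assay. Among the measured compounds shown here, two of the three values therefore sit at the limit of > 100000 nM in this assay, at which 2 of the 3 values shown sit, and the single step between compounds differing in one place, a step that the two limits leave unreadable from compound 1 to compound 3, cannot be read from them. For the measured compounds named here, compound 2 thus stands alone as the one compound with a numerical result, and nothing in the set ranks it against the others beyond the fact that it falls inside the measurable window.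

Compound 4 `C#CSc1nc2nc(C)cc(N3CC[C@@H](C)[C@@H](N(C)c4ncnc5[nH]ccc45)C3)n2n1` is the next compound to be measured in this assay. It differs from compound 2 in one place:

ethynyl in place of cyclohexylmethyl on a sulfur

Going by the values given here, no measured step touches the group on this sulfur: the only step between compounds that differ in one place concerns another position and is unreadable in any case. The expectation for compound 4 therefore rests on compound 2 alone, with a wide range. The step from compound 2 to compound 4 is estimated as a 2.6-fold higher number from compound 2 to compound 4 (0.42 log units; beyond the scatter), leaning toward weaker inhibition but with a real chance of no change beyond the scatter. Compound 4 is expected to give about 30000 nM in this assay, between 8000 nM and 100000 nM.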

Compound 4, half-maximal inhibitory concentration: 35100 nM
Estimate against measurement, compound 4: 1.2-fold (0.07 log units) below, and the stated range covers the measured number.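

In this assay, among these compounds, the group on the sulfur gives the first readable step: ethynyl in place of cyclohexylmethyl produces a 3.1-fold higher number from compound 2 to compound 4 (0.48 log units; beyond the scatter) and is a modest change. The six-membered non-aromatic ring of carbon only can therefore give way to a small ring-free group with a triple bond while the result stays a number, with compound 4 at 35100 nM in this assay. Among the compounds shown here, this is the only comparison on this position, and the one earlier step, between compound 1 and compound 3, cannot be read: the limit of > 100000 nM in this assay, at which 2 of the 4 values shown sit.

A single step cannot separate the loss of the ring from the shortening of the group or the arrival of the triple bond, so it gives no trend for this sulfur. On these data alone, how a simple methyl, a saturated chain such as propyl, or a chain ending in an amine or a carboxylic acid would compare on this sulfur stays open, as does whether the step would keep its size with other groups on the shared core.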